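The compounds below may be only part of what the source reports. "The series", "measured", "known", "first", "only" and "open" are said of these compounds alone.

Measured in a functional assay on L1210 cells (Mus musculus) for antiproliferative activity; on this read-out lower numbers stand for stronger inhibition and higher numbers for weaker inhibition:
compound 1 `C=C1C(=O)ON(C)C1C(C)CCC` gives 1900 nM
compound 2 `C=C1C(=O)ON(C)C1c1ccc(C)cc1` gives 800 nM
compound 3 `C=C1C(=O)ON(C)C1c1ccc(OC)cc1` gives 3500 nM

Compound 2 stands lowest of the three in this assay; compound 1 and compound 3 both give higher numbers, each beyond the scatter. Compound 4 `C=C1C(=O)ON(C)C1c1ccc([N+](=O)[O-])cc1` differs from compound 2 by nitro in place of methyl on an aromatic carbon. Among the measured compounds shown here, the only step that bears on this is the exchange at the same aromatic carbon, a 4.4-fold higher number from compound 2 to compound 3 (0.64 log units; beyond the scatter), which raised the number when methoxy replaced methyl. Nitro is a third group at that position, so no direct precedent exists; a modest rise from compound 2 is the most cautious expectation, with wide uncertainty. Compound 4 is therefore expected to give 1600 nM, within 500 nM to 5000 nM. The expected step is a 2.0-fold higher number from compound 2 to compound 4 (0.30 log units; within the scatter).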

Compound 4, half-maximal inhibitory concentration: 800 nM
For compound 4 the middle estimate is 2.0-fold (0.30 log units) above the measured one; the range from low to high includes it.
By their numbers in this assay, from the lowest: compounds 2 and 4 (each within the scatter of the next); then compounds 1 and 3 (each within the scatter of the next).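

At this aromatic carbon in this assay, nitro in place of methyl gives no change at the digits printed from compound 2 to compound 4 (within the scatter) and so does not repeat the rise seen with methoxy. Nitro in place of methoxy gives a 4.4-fold lower number from compound 3 to compound 4 (0.64 log units; beyond the scatter) and thus shows that the higher number is not shared by every replacement of methyl: among these three groups, only methoxy stands apart. Nothing available accounts for this separation. On these data alone, whether an amine or a carboxylic acid at this carbon would align with methyl and nitro or with methoxy remains open.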